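A few compounds are considered here, and "the series" means these few. Any claim that something is new, unique, unknown or untested is made for them only; others in the source may bear on it.

Compounds measured: compound 1 `O=C(NCc1cc(Cl)ccc1-n1cnnn1)[C@@H]1CC=NN1C(=O)[C@H](O)c1ccccc1F` with 1100 nM; compound 2 `O=C(NCc1cc(Cl)ccc1-n1cnnn1)[C@@H]1CC=NN1C(=O)[C@H](O)Cc1ccccc1` with 1400 nM; compound 3 `O=C(NCc1cc(Cl)ccc1-n1cnnn1)[C@@H]1[C@@H]2C[C@@H]2CN1C(=O)[C@H](O)c1ccccc1F` with 580 nM.

All three were tested in a functional assay on a cell-free system (plasma, Homo sapiens), with a stated time of 3 min; on this read-out lower numbers stand for stronger inhibition and higher numbers for weaker inhibition. Compound 1 and compound 2 share a core and differ in one place: benzyl in place of 2-fluorophenyl on a saturated chain carbon bound to a carbonyl carbon and an oxygen on a saturated carbon. That change gave a 1.3-fold higher number from compound 1 to compound 2 (0.10 log units; within the scatter). Compound 3 carries a different core; how its core differs from that of compound 1 is not broken down here. In this assay compound 3 gives 580 nM, a number that is within the scatter of compound 1 but clearly lower than that of compound 2.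

Compound 4 `O=C(NCc1cc(Cl)ccc1-n1cnnn1)[C@@H]1[C@@H]2C[C@@H]2CN1C(=O)[C@H](O)Cc1ccccc1` is not yet measured. It relates to compound 3 exactly as compound 2 relates to compound 1, since the change is the same in both pairs: benzyl in place of 2-fluorophenyl on a saturated chain carbon bound to a carbonyl carbon and an oxygen on a saturated carbon. Because the earlier step of a 1.3-fold higher number from compound 1 to compound 2 (0.10 log units; within the scatter) stayed within the scatter, the same change on the core of compound 3 is expected to behave alike, giving a 1.3-fold higher number from compound 3 to compound 4 (0.11 log units; within the scatter). Compound 4 is therefore estimated at 750 nM, with a likely range from 350 nM to 1600 nM.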

Compound 4, half-maximal inhibitory concentration: 970 nM
Compound 4: middle estimate off by 1.3-fold (0.11 log units), on the low side; the range from low to high includes it.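

Moved to the other core, benzyl in place of 2-fluorophenyl gave a 1.7-fold higher number from compound 3 to compound 4 (0.22 log units; within the scatter) in this assay. Set beside the earlier step, the change shows no measurable dependence on the core: the same change on two cores in this assay, a 1.3-fold higher number (0.10 log units; within the scatter) from compound 1 to compound 2 and a 1.7-fold higher number (0.22 log units; within the scatter) from compound 3 to compound 4, 1.3-fold (0.12 log units) apart, within the scatter of two such steps. This supports carrying the change between these two cores as a small step that stays within the scatter on each, but it rests on just two pairs of compounds; it does not show that the two steps are identical, nor that a third core would behave the same way.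

The compounds shown leave open what happens on either core when the group on this saturated chain carbon is something other than 2-fluorophenyl or benzyl, such as a longer chain like phenethyl, a cyclohexyl ring or a group carrying a carboxylic acid. They also leave open whether an amine in place of the oxygen on that carbon would fit the same picture.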